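Series notes: cytotoxicity step from compound 3 to compound 4

The source may report more compounds than this note shows. Statements on the series, on what has been measured and on what is new or still open speak of the compounds shown alone.

Measured so far:
compound 1 `COc1cccc(Oc2ccc3c(NCCCNCc4cccc(OC)c4O)ccnc3c2)c1` — 5300 nM
compound 2 `COc1cccc(CNCCCNc2ccnc3cc(CCC(C)C)ccc23)c1O` — 5390 nM
compound 3 `COc1ccc(F)cc1CNCCCNc1ccnc2cc(-c3cccc4ccccc34)ccc12` — 16000 nM

All three numbers come from an ADME assay on HepG2 cells (Homo sapiens) for cytotoxicity, read by luminescence, CellTiter-Glo and ATP content, with a stated time of 72 h; on this read-out lower numbers stand for an effect already at smaller amounts and higher numbers for an effect only at larger amounts of compound. Compound 3 stands highest of the three; compound 2 is nearest, and both compound 2 and compound 1 lie beyond the scatter below it. Going by the values given here, the only measured step between compounds differing in one place is a 1.0-fold higher number from compound 1 to compound 2 (0.01 log units; within the scatter); it exchanges the group on an aromatic carbon of the shared core, leaves the head group untouched, and stays within the scatter, so it bears only indirectly on the present change.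

Compound 4 `COc1cccc(CNCCCNc2ccnc3cc(-c4cccc5ccccc45)ccc23)c1O` keeps the remainder of compound 3 and differs only in the head group: 2-hydroxy-3-methoxyphenyl in place of 5-fluoro-2-methoxyphenyl on a saturated chain carbon bound to an amine nitrogen. Among the compounds with values here, the entering head is the one carried by compound 1 and compound 2, both of which give lower numbers than compound 3 in this assay, though no single-point step isolates that change. On that basis a modest move toward lower numbers is expected, a 1.8-fold lower number from compound 3 to compound 4 (0.25 log units; within the scatter), with no firm claim beyond the scatter. The estimate for compound 4 is 9000 nM, expected between 4000 nM and 20000 nM.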

Compound 4, half-maximal effective concentration: 2520 nM
The estimate for compound 4 lay 3.6-fold (0.55 log units) above the measured number; the measured number lies below the stated range.
By their numbers in this assay, from the lowest: compound 4; then compounds 1 and 2 (each within the scatter of the next); then compound 3.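

In this assay the head group on the saturated chain carbon bound to an amine nitrogen now has a reading of its own: 2-hydroxy-3-methoxyphenyl in place of 5-fluoro-2-methoxyphenyl, with all else fixed, moves the number beyond the scatter (a 6.3-fold lower number from compound 3 to compound 4 (0.80 log units; beyond the scatter)). With the 2-hydroxy-3-methoxyphenyl head held fixed, the group on the aromatic carbon also registers, since naphthalen-1-yl differs beyond the scatter from both isopentyl (a 2.1-fold lower number from compound 2 to compound 4 (0.33 log units; beyond the scatter)) and 3-methoxyphenoxy (a 2.1-fold lower number from compound 1 to compound 4 (0.32 log units; beyond the scatter)), whereas the exchange between those two stayed within it (a 1.0-fold higher number from compound 1 to compound 2 (0.01 log units; within the scatter)). No accompanying measurement bears on the cause of these steps.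

Open, on these data alone, is which part of the entering head carries the step, which a 2-hydroxyphenyl or a 3-methoxyphenyl head on the same carbon would separate. Also open, as far as these compounds go, is whether the step survives a longer chain between the two amine nitrogens.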